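Hydrazones on a shared core: from methoxyphenyl to fluorophenyl

The source may report more compounds than this note shows. Statements on the series, on what has been measured and on what is new or still open speak of the compounds shown alone.

Compound 1 `Cc1c(C(=O)N/N=C\c2c(O)cccc2F)oc2cccc(O)c12` in a functional assay on PC-3 cells (Homo sapiens) for inhibition (on this read-out higher numbers stand for weaker inhibition and lower numbers for stronger inhibition), gives 8050 nM. Compound 2 `Cc1ccc(O)c(/C=N\NC(=O)c2oc3cccc(O)c3c2C)c1` gives 7350 nM. Compound 3 `COc1cccc(/C=N\NC(=O)c2oc3cccc(O)c3c2C)c1` gives only an assay limit, >= 40000 nM.

Compound 3 therefore sits at the limit of >= 40000 nM in this assay, at which 1 of the 3 values shown sits, with no exact number. Compound 4 `Cc1c(C(=O)N/N=C\c2ccc(F)cc2)oc2cccc(O)c12` differs from it in one place: 4-fluorophenyl in place of 3-methoxyphenyl on a carbon with a double bond to nitrogen. Two measured steps lead to compound 3 and so bear on this: an at least 4.9-fold higher number from compound 1 to compound 3 (0.69 log units; beyond the scatter) and an at least 5.4-fold higher number from compound 2 to compound 3 (0.73 log units; beyond the scatter), each at least modest. Both partners that lose to compound 3 carry a hydroxyl on the aryl; compound 4, like compound 3, has none. A step of an at least 1.3-fold lower number from compound 3 to compound 4 (0.12 log units; that floor lies within the scatter) is therefore expected, perhaps no gain, perhaps a modest one. Compound 4 is estimated at 30000 nM, within 8000 nM to 100000 nM.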

Compound 4, half-maximal inhibitory concentration: >= 40000 nM
Compound 4: a limit, no number; the forecaster's own chance of this, stated with the estimate: 50%; middle value at least 1.3-fold (0.12 log units) from the limit.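

Compound 4 also reaches only a limit in this assay, so 4-fluorophenyl, like 3-methoxyphenyl, is an aryl group without a hydroxyl that gives no exact number at this position: the limit of >= 40000 nM in this assay, at which 2 of the 4 values shown sit. The hydroxyl-bearing partners compare clearly, with an at least 5.4-fold higher number from compound 2 to compound 4 (0.73 log units; beyond the scatter) and an at least 4.9-fold higher number from compound 1 to compound 4 (0.69 log units; beyond the scatter), and none of the four compounds goes against this pattern. The step between compound 3 and compound 4 cannot be read.

As far as these compounds go, the true values of compound 3 and compound 4 stay open. So does the effect of an aryl group carrying an amine or a carboxylic acid on this carbon.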